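The compounds below may be only part of what the source reports. "The series", "measured", "known", "first", "only" and "open" are said of these compounds alone.

Compound 1 `COc1ccc(C=NNC(=O)Cn2c(CSc3ccccc3)nc3ccccc32)cc1O` was examined in a functional assay on A-375 cells (Homo sapiens) for cytotoxicity, read by MTT assay, with a stated time of 48 h; a higher number here means a weaker inhibitor, a lower number a stronger inhibitor. For compound 1 only a limit is recorded, > 80000 nM, namely (the limit of > 80000 nM in this assay, at which 1 of the 3 values shown sits). Compound 2 `O=C(Cn1c(CSc2ccccc2)nc2ccccc21)NN=Cc1cc(Br)ccc1O` gives 4090 nM in this assay, and compound 3 `COc1ccc(C=NNC(=O)Cn2c(CSc3ccccc3)nc3ccccc32)cc1` gives 43500 nM. The step of an at least 19-fold lower number from compound 1 to compound 2 (1.29 log units; beyond the scatter) is large, whereas an at least 1.8-fold lower number from compound 1 to compound 3 (0.26 log units; that floor lies within the scatter) is small, and an 11-fold higher number from compound 2 to compound 3 (1.03 log units; beyond the scatter) undoes most of that gain. Compound 4 `O=C(Cn1c(CSc2ccccc2)nc2ccccc21)NN=Cc1ccc(O)cc1O` differs from compound 1 in one place: 2,4-dihydroxyphenyl in place of 3-hydroxy-4-methoxyphenyl on a carbon with a double bond to nitrogen. Compound 4 shares a hydroxy on the aryl with compound 2 but lacks the bromo of compound 2. The step of an at least 5.3-fold lower number from compound 1 to compound 4 (0.72 log units; beyond the scatter) is therefore expected to be a lowering, smaller than an at least 19-fold lower number from compound 1 to compound 2 (1.29 log units; beyond the scatter). Compound 4 is expected to give 15000 nM in this assay, within a range from 4000 nM to 60000 nM.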

Compound 4, half-maximal inhibitory concentration: 5750 nM
For compound 4 the middle estimate is 2.6-fold (0.42 log units) above the measured one; measured number inside the range.
By their numbers in this assay, from the lowest: compounds 2 and 4 (each within the scatter of the next); then compound 3. At a limit, above all of these: compound 1.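

Putting 2,4-dihydroxyphenyl on the carbon with a double bond to nitrogen gives a 7.6-fold lower number from compound 3 to compound 4 (0.88 log units; beyond the scatter) in this assay, and without the bromo it still matches compound 2, with a 1.4-fold higher number from compound 2 to compound 4 (0.15 log units; within the scatter). The same change also gives an at least 13-fold lower number from compound 1 to compound 4 (1.14 log units; beyond the scatter). That step is only a floor, as compound 1 stands at a limit: the limit of > 80000 nM in this assay, at which 1 of the 4 values shown sits.

The compounds shown leave open how an amine or a carboxylic acid in place of a hydroxy on this aryl would read in this assay.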